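The source may hold more compounds than are shown below. What is called first, only, known or untested is meant among the compounds shown, and "the series" means these compounds.

Measured so far in a functional assay on the whole organism (strain albino) for inhibition, with Rattus norvegicus as the target, read by paw edema, with stated times of 1 h and 2 h, at a dose of 20 mmol/kg by the intraperitoneal route; a lower number here means less inhibition, a higher number more inhibition at the dose given (going by the name of the read-out):
compound 1, `N#CC1=C(NCN2CCCC2)N(c2ccccc2)C(=O)N2CCCCC(N3CCCC3)C12`, gives 26.6%
compound 2, `N#CC1=C(/N=C/Nc2ccc([N+](=O)[O-])cc2)N(c2ccccc2)C(=O)N2CCCCC(N3CCCC3)C12`, gives 41.5%

Compound 2 stands highest of the two numbers; its nearest neighbour is compound 1, and the step of a number 14.9 percentage points higher from compound 1 to compound 2 (beyond the scatter) lies beyond the scatter. Compound 3, `N#CC1=C(NCC(=O)N2CCCC2)N(c2ccccc2)C(=O)N2CCCCC(N3CCCC3)C12`, has not yet been measured. It differs from compound 2 in one place: a group of 9 heavy atoms (6 carbon, 2 nitrogen, 1 oxygen; one five-membered non-aromatic ring with 1 hetero atom) in place of a group of 12 heavy atoms (7 carbon, 3 nitrogen, 2 oxygen; one six-membered aromatic ring of carbon only), on a double-bonded ring carbon. Within the data shown here, the only step that bears on this change is the one from compound 1 to compound 2, where a five-membered non-aromatic ring bearing group gave way to a larger group with a six-membered aromatic ring, and the read-out rose by a number 14.9 percentage points higher from compound 1 to compound 2 (beyond the scatter). Compound 3 brings a five-membered non-aromatic ring back, so a step in the opposite direction is expected. The expected step is a number 11.5 percentage points lower from compound 2 to compound 3 (beyond the scatter), a modest fall. For compound 3 the estimate is 30%, with a range from 15% to 45%.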

Compound 3, a percentage reported as inhibition, in the whole organism at one dose (the size of the read-out at that dose, not a potency): 49.8%
Compound 3: the middle estimate sits 19.8 percentage points below what was measured, and the stated range ends below it.
By their numbers in this assay, from the lowest: compound 1; then compounds 2 and 3 (each within the scatter of the next).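

In this assay, a five-membered non-aromatic ring at this place does not by itself go with a low number: the (((pyrrolidin-1-yl)carbonyl)methyl)amino group of compound 3 and the larger aromatic group of compound 2 cannot be told apart (a number 8.3 percentage points higher from compound 2 to compound 3 (within the scatter)). Among these compounds, the single change that does separate compounds is the carbonyl, with (pyrrolidin-1-yl)carbonyl in place of pyrrolidin-1-yl on a saturated chain carbon bound to an amine nitrogen (a number 23.2 percentage points higher from compound 1 to compound 3 (beyond the scatter)), so within these compounds the ring alone does not set the read-out. Nothing measured here explains why the carbonyl goes with this rise.

The compounds shown leave open whether the rise depends on the pyrrolidine ring, which a morpholine or a diethylamino group on the same carbonyl would test. They also leave open how a longer chain ahead of the carbonyl would read.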